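A few compounds are considered here, and "the series" means these few. Any claim that something is new, unique, unknown or untested is made for them only; others in the source may bear on it.

In a functional assay on MDA-MB-231 cells (Homo sapiens) for cytotoxicity, read by MTT assay, with a stated time of 48 h (on this read-out lower numbers stand for stronger inhibition and higher numbers for weaker inhibition), compound 1 `CCn1c(/C=C2/C(=O)Nc3ccc(F)cc32)nc2ccccc21` reads > 50000 nM, which is a limit of the assay and not a number. Compound 2 `CCn1c(/C=C2/C(=O)Nc3ccccc32)nc2ccccc21` reads > 50000 nM, also a limit. Compound 3 `CCn1c(/C=C2/C(=O)Nc3ccc(C)cc32)nc2ccccc21` gives 40600 nM. Compound 1 therefore stands at the limit of > 50000 nM in this assay, at which 2 of the 3 values shown sit.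

Compound 4 `Cn1c(/C=C2/C(=O)Nc3ccc(F)cc32)nc2ccccc21` differs from compound 1 by hydrogen in place of methyl on a saturated chain carbon bound to an aromatic nitrogen, which shortens ethyl to methyl. The measured changes all sit on an aromatic carbon: a step that the two limits leave unreadable from compound 1 to compound 2, an at least 1.2-fold lower number from compound 1 to compound 3 (0.09 log units; that floor lies within the scatter) and an at least 1.2-fold lower number from compound 2 to compound 3 (0.09 log units; that floor lies within the scatter). None of them touches the chain, so they bear on this change only indirectly, and no step beyond the scatter is expected in this assay. The expected step is a number no higher from compound 1 to compound 4 (the limit leaves the size open). Compound 4 is estimated at 50000 nM, with an expected range of 25000 nM to 100000 nM.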

Compound 4, half-maximal inhibitory concentration: 21700 nM
Estimate against measurement, compound 4: 2.3-fold (0.36 log units) above; measured number below the stated range.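

In this assay, shortening ethyl to methyl on the saturated chain carbon bound to an aromatic nitrogen gives an at least 2.3-fold lower number from compound 1 to compound 4 (0.36 log units; beyond the scatter). For the compounds shown here, this is the first step that is readable as beyond the scatter: the earlier changes on an aromatic carbon either stayed within it or could not be read. The step is only a floor, as compound 1 reads a limit: the limit of > 50000 nM in this assay, at which 2 of the 4 values shown sit.

From the compounds shown here alone, whether a propyl or longer chain, or a chain carrying an amine, would shift the number stays open. So does whether shortening ethyl to methyl has the same effect with hydrogen or methyl in place of fluoro on the aromatic carbon.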